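The source may report more compounds than this note shows. Statements on the series, on what has been measured and on what is new or still open speak of the compounds shown alone.

Measured in an ADME assay on MT4 cells (Homo sapiens) for cytotoxicity, read by MTT assay, with a stated time of 4 days; a higher number here means that more compound is tolerated, a lower number that less compound is tolerated:
compound 1 `Cc1cc(C#N)cc(C)c1Oc1ccnc(SCC(=O)Nc2ccc(C#N)cc2)n1`: > 300000 nM, a limit of the assay
compound 2 `Cc1ccc(NC(=O)CS(=O)(=O)c2nccc(Oc3c(C)cc(C#N)cc3C)n2)cc1C`: 13900 nM
compound 3 `COc1ccc(NC(=O)CS(=O)(=O)c2nccc(Oc3c(C)cc(C#N)cc3C)n2)cc1`: 5110 nM

Compound 1 stands at a limit and so gives no number. Of the two actual numbers in this assay, the higher belongs to compound 2 at 13900 nM, and its nearest neighbour is compound 3.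

Compound 4 `Cc1cc(C#N)cc(C)c1Oc1ccnc(S(=O)(=O)CC(=O)Nc2cccc(F)c2)n1` carries 3-fluorophenyl in place of 3,4-dimethylphenyl on an amide-type nitrogen. Among the measured compounds shown here, only one measured step changes the group at this place: a 2.7-fold lower number from compound 2 to compound 3 (0.43 log units; beyond the scatter), a modest change that replaces 3,4-dimethylphenyl with 4-methoxyphenyl. This is thin ground, as a single step gives direction and size from one example only. A similar modest move towards a lower number is therefore expected for compound 4, resting on compound 3 and its step of a 2.7-fold lower number from compound 2 to compound 3 (0.43 log units; beyond the scatter).

The estimated change is a 1.7-fold lower number from compound 2 to compound 4 (0.24 log units; within the scatter).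

For compound 4 the estimated value is 8000 nM, with an expected range of 2500 nM to 28000 nM.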

Compound 4, half-maximal cytotoxic concentration: 25900 nM
For compound 4 the middle estimate is 3.2-fold (0.51 log units) below the measured one; the range from low to high includes it.
By their numbers in this assay, from the lowest: compound 3; then compounds 2 and 4 (each within the scatter of the next). At a limit, above all of these: compound 1.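

In this assay the change to 3-fluorophenyl on the amide-type nitrogen does not separate compound 4 from the 3,4-dimethylphenyl group of compound 2 (a 1.9-fold higher number from compound 2 to compound 4 (0.27 log units; within the scatter)). The lower number of compound 3 therefore does not carry over to every replacement at this place, since 3-fluorophenyl and 4-methoxyphenyl clearly part (a 5.1-fold higher number from compound 3 to compound 4 (0.70 log units; beyond the scatter)). Of the three groups shown here, only 4-methoxyphenyl stands apart from both others, so one of the two replacements moves the number beyond the scatter and the other does not.

Open, going by these compounds, is whether a cyclohexyl ring, a short alkyl chain, or a phenyl ring carrying an amine or a carboxylic acid on this nitrogen would fall with compound 3 or with compounds 2 and 4. No measurement at hand accounts for the gap between 4-methoxyphenyl and the other two groups.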